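From Methoxy to Benzoyl: Estimating Growth Inhibition

The compounds below may be only part of what the source reports. "The series", "measured", "known", "first", "only" and "open" are said of these compounds alone.

In a functional assay on HepG2 cells (Homo sapiens) for inhibition, read by MTT assay, with a stated time of 72 h, tested at 50 uM (a higher number here means more inhibition of growth at the concentration tested, a lower number less inhibition of growth), two compounds have been measured so far:

Compound 1, `C=CCc1ccc(OCc2cn(-c3ccc(C#N)cc3)nn2)c(O)c1`, gives 12.1%.
Compound 2, `C=CCc1ccc(OCc2cn(-c3ccc(OC)cc3)nn2)c(O)c1`, gives 49.9%.

Going by the values given here, compound 2 stands highest of these two numbers; its only neighbour is compound 1, and the step of a number 37.8 percentage points higher from compound 1 to compound 2 (beyond the scatter) lies beyond the scatter. Compound 3, `C=CCc1ccc(OCc2cn(-c3ccc(C(=O)c4ccccc4)cc3)nn2)c(O)c1`, differs from compound 2 in one place: benzoyl in place of methoxy on an aromatic carbon, on an aromatic carbon of a six-membered aromatic ring of carbon only, para to a large group. Among the compounds with values here, only one measured step bears on this position, a number 37.8 percentage points higher from compound 1 to compound 2 (beyond the scatter), and it shows that exchanging the group here can move the reading a long way. Benzoyl is neither cyano nor methoxy, so there is no measured precedent for it, and the direction of the change is open. The expectation for compound 3 is therefore a number set somewhat below compound 2, with a wide range covering both measured values. The step of a number 11.9 percentage points lower from compound 2 to compound 3 (beyond the scatter) is the estimated change. Compound 3 is estimated at 38%, between 10% and 66%.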

Compound 3, percent growth inhibition at one concentration: 16.2%
The estimate for compound 3 lay 21.8 percentage points above the measured number, and the stated range covers the measured number.
By their numbers in this assay, from the lowest: compounds 1 and 3 (each within the scatter of the next); then compound 2.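

In this assay, from the compounds shown here alone, this second exchange at the position settles the direction that was still open, since the step to benzoyl is large and downward (a number 33.7 percentage points lower from compound 2 to compound 3 (beyond the scatter)). Benzoyl and nitrile also give readings that cannot be told apart (a number 4.1 percentage points higher from compound 1 to compound 3 (within the scatter)), even though benzoyl brings a whole six-membered aromatic ring to this carbon. Among these three compounds, which share the same core and differ only in this one group, methoxy alone stands clearly apart, so the higher reading of compound 2 goes with that group and not with the core.

Still open, going by these compounds, is whether the reading depends on methoxy itself or would also hold with a longer ether such as ethoxy, with a free hydroxyl, or with an amine on the same carbon, and a single methoxy compound cannot answer that. Nothing in the available data gives a reason for the gap between methoxy and the other two groups.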